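Sulfonamide series: shortening the chain on compound 3

A few compounds are considered here, and "the series" means these few. Any claim that something is new, unique, unknown or untested is made for them only; others in the source may bear on it.

Measured compounds, antiproliferative read-out at one concentration:
compound 1 `CC(=O)Nc1nc(-c2cccc(NS(=O)(=O)c3ccc(C#C[Si](C)(C)C)cc3)c2)cs1` gives < 1%
compound 2 `CCCCCCCCC#Cc1ccc(S(=O)(=O)Nc2cccc(-c3csc(NC(C)=O)n3)c2)cc1` gives < 1%
compound 3 `CCCCCCCCc1ccc(S(=O)(=O)Nc2cccc(-c3csc(NC(C)=O)n3)c2)cc1` gives < 1%

In a functional assay on A-375 cells (Homo sapiens) for antiproliferative activity, read by trypan blue exclusion, with a stated time of 48 h, tested at 10 uM (a lower number here means a stronger effect, a higher number a weaker effect of the compound at the concentration tested), compound 3 gives < 1%, which is a limit of the assay and not a number. Compound 1 in this assay also sits at a limit, < 1%. Compound 2 in this assay sits at a limit as well, < 1%. Where compound 3 stands on the measured scale therefore cannot be placed: the three values shown all rest on (the limit of < 1% in this assay, at which 3 of the 3 values shown sit), so none of the three compounds can be put above or below another.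

The step to compound 4 `CCCCCCc1ccc(S(=O)(=O)Nc2cccc(-c3csc(NC(C)=O)n3)c2)cc1` is hydrogen in place of ethyl on a saturated chain carbon, six bonds along the chain from an aromatic carbon. The steps measured so far, a step that the two limits leave unreadable from compound 1 to compound 2, a step that the two limits leave unreadable from compound 1 to compound 3 and a step that the two limits leave unreadable from compound 2 to compound 3, all concern the same end of the molecule, the chain on the aromatic carbon of the sulfonyl-bearing ring, but each runs between two limits and so tells nothing about size or direction. For the measured compounds named here, no measured step gives a readable size for a chain shortening of this kind. The expectation for the step from compound 3 to compound 4 in this assay is accordingly a number no lower from compound 3 to compound 4 (the limit leaves the size open), with compound 4 most likely remaining at the same limit. For compound 4 the estimated value in this assay is 1%, within 0% to 8%.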

Compound 4, a percentage reported as activity, at one concentration (the size of the read-out at that concentration, not a potency): <= 1%
Compound 4: a limit, no number; the forecaster's own chance of this, stated with the estimate: 0.8%; the middle value lies on the limit itself.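

In this assay compound 4 gives <= 1%, a limit of the assay and not a number. The steps to compound 4 from compound 1, compound 2 and compound 3 cannot be read. The compounds shown leave open how the hexyl, octyl and dec-1-yn-1-yl chains rank against one another, and whether any shorter chain would leave the limit.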